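One Flipped Ring Centre in a Peroxide Acid

The source may hold more compounds than are shown below. What is called first, only, known or untested is meant among the compounds shown, and "the series" means these compounds.

Of the compounds shown here, two have been measured so far. In a functional assay on BT-549 cells (Homo sapiens) for inhibition (a lower number here means a stronger inhibitor of growth, a higher number a weaker inhibitor of growth), compound 1 `C=C1CCC[C@H]2[C@](C)(CC[C@]3(C)CC[C@@H]([C@@H](C)C(=O)O)OO3)[C@@H](C)CC[C@]12C` gives 960 nM, the lowest of the two numbers. Compound 2 `C=C1CCCC(C)(C)C1CC[C@@]1(C)CC[C@H]([C@@H](C)C(=O)O)OO1` gives 1050 nM in this assay, and this number lies within the usual scatter of the number for compound 1, so the two cannot be told apart on potency. For the measured compounds named here, no pair of measured compounds differs in just one place, so no single structural change has yet been tied to a shift in growth inhibition.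

Compound 3 `C=C1CCC[C@H]2[C@](C)(CC[C@]3(C)CC[C@H]([C@@H](C)C(=O)O)OO3)[C@@H](C)CC[C@]12C` has not been measured. It differs from compound 1 in this way: the two compounds have the same atoms and bonds and differ only in configuration as drawn: 1 of 7 stereo elements differ; a stereocentre at a saturated ring carbon is drawn S in compound 1 and R in compound 3. Every atom and bond is kept, so the comparison asks one question only: whether the other arrangement at this one ring carbon alters how strongly the cells are held back. Going by the values given here, no measured step speaks to this, so the expectation stays close to compound 1 with a wide allowance. The step of a 1.4-fold higher number from compound 1 to compound 3 (0.13 log units; within the scatter) is expected to be small, within or only just beyond the scatter, toward a slightly weaker inhibitor. Compound 3 is estimated at 1300 nM, with a range from 400 nM to 4000 nM.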

Compound 3, concentration for 50% growth inhibition: 1810 nM
Beside the measured number, compound 3's estimate is 1.4-fold (0.14 log units) below it, within the range that was stated.
By their numbers in this assay, from the lowest: compounds 1, 2 and 3 (each within the scatter of the next).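

In this assay, changing the arrangement at this one ring carbon gives a 1.9-fold higher number from compound 1 to compound 3 (0.28 log units; within the scatter), so the S and R forms cannot be told apart on growth inhibition. For the compounds shown here, this is the first comparison that isolates a single change, and it can be read cleanly because nothing else separates the two compounds: the fact that compounds 1 and 3 differ only in the configuration as drawn. For this carbon on the core of compound 1, then, the arrangement drawn does not shift growth inhibition by more than repeated measurements of the same compound would be expected to, although this rests on one pair and says nothing about other positions.

From the compounds shown here alone, the remaining stereo elements of the core are still untested by any single-place comparison, as is whether the same change at this carbon would behave alike in the simpler structure of compound 2. It is also open whether a methyl ester or an amide in place of the carboxylic acid would keep growth inhibition at this level, since every compound shown carries the free acid.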